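The compounds below may be only part of what the source reports. "The series", "measured", "known", "first", "only" and "open" are said of these compounds alone.

Compound 1 `COc1cc2c(=O)c(C(=O)c3ccc(C)cc3)cn(CC3CCCCC3)c2cc1OC` carries the highest of the two numbers given here: in an ADME assay on Huh-7 cells (Homo sapiens) for cytotoxicity (a higher number here means a weaker inhibitor of growth, a lower number a stronger inhibitor of growth), compound 1 gives 22000 nM, while compound 2 `COc1cc2c(=O)c(C(=O)OCc3cccc(C)c3)cn(Cc3ccc(C(F)(F)F)cc3F)c2cc1OC` in this assay gives 7300 nM, a lower number that lies beyond the usual scatter. Compound 3 `CN1CCN(c2cc3c(cc2F)c(=O)c(NC(=O)NCc2ccccc2)cn3Cc2ccccc2)CC1` is recorded in this assay as "not active" (no number reported), with no number attached. Compound 4 `COc1cc2c(=O)c(C(=O)c3ccc(C)cc3)cn(Cc3ccc(C(C)(C)C)cc3)c2cc1OC` is not yet measured and differs from compound 1 in one place: 4-(tert-butyl)phenyl in place of cyclohexyl on a saturated chain carbon bound to an aromatic nitrogen. No pair of measured compounds differs in a single place, so nothing shown here tells how such a change moves the readout. The step of a 1.5-fold lower number from compound 1 to compound 4 (0.17 log units; within the scatter) is expected to be small and toward a lower number, at or just beyond the scatter. For compound 4 a value of about 15000 nM is estimated, within 6000 nM to 40000 nM.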

Compound 4, concentration for 50% growth inhibition: > 25000 nM
Compound 4: no number, only a limit; the forecaster's own chance of this, stated with the estimate: 20%; middle value at least 1.6-fold (0.22 log units) away from the limit.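

Compound 4 gives only a limit in this assay, not a number, so the comparison with compound 1 has a floor and no exact size. This is the first single-place comparison shown at this position: 4-(tert-butyl)phenyl in place of cyclohexyl gives an at least 1.1-fold higher number from compound 1 to compound 4 (0.05 log units; that floor lies within the scatter). The change therefore brings no measurable gain in growth inhibition, and how far the number rises cannot be read: the limit of > 25000 nM in this assay, at which 1 of the 4 values shown sits.

Still open, on these data alone, is how an amine or a carboxylic acid at this place would move the number. A longer chain between the aromatic nitrogen and the ring is equally untested here.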